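Compound 3 to compound 4: hydroxy in place of nitro

This account rests on a few compounds, and the source may have more. Where it says the series, first, only, none or still open, it means among the compounds named here.

Measured in a functional assay on the whole organism (strain Sprague-Dawley) for inhibition, with Rattus norvegicus as the target, with a stated time of 10 min; a higher number here means that more compound is needed for the effect, a lower number that less compound is needed:
Compound 1 `O=C(O)c1cnc(-c2ccccc2[N+](=O)[O-])[nH]c1=O`: > 50 mg/kg, a limit
Compound 2 `O=C(O)c1cnc(-c2ccccc2O)[nH]c1=O`: > 5 mg/kg, a limit
Compound 3 `CCOC(=O)c1cnc(-c2ccccc2[N+](=O)[O-])[nH]c1=O`: "not determined" (no result reported)

Compound 3 has no number to start from, and the other two compounds give limits only. The change to compound 4 `CCOC(=O)c1cnc(-c2ccccc2O)[nH]c1=O` is hydroxy in place of nitro on an aromatic carbon. For the measured compounds named here, the one measured step with this change is a step that the two limits leave unreadable from compound 1 to compound 2, so neither its size nor its direction carries over. Going by the values given here, no particular step in this assay is therefore expected. Compound 4 shares the hydroxy of compound 2, which gives > 5 mg/kg, a limit. For compound 4 the estimated value is 10 mg/kg, with an expected range of 2 mg/kg to 50 mg/kg.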

Compound 4, dose for 50% inhibition: 5 mg/kg
The estimate for compound 4 lay 2.0-fold (0.30 log units) above the measured number; low and high end bracket the measured number.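

Compound 4 gives the first number rather than a limit in this assay, so a hydroxy on this aromatic carbon can go with a measurable dose when ethyl sits on the oxygen next to the carbonyl group. Ethyl in place of hydrogen there gives a number no higher from compound 2 to compound 4 (the limit leaves the size open). Compound 2 remains a limit at > 5 mg/kg.

The effect of hydroxy in place of nitro cannot be read in either pair. Still open, from the compounds shown here alone, is whether an amine in place of the hydroxy, or a longer chain in place of the ethyl, keeps a measurable dose.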